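This account rests on a few compounds, and the source may have more. Where it says the series, first, only, none or still open, it means among the compounds named here.

Compound 1, `COc1cc(C#N)ccc1OCc1nnc(-c2ccc(C)cc2)o1`, and compound 2, `COc1cc(C#N)ccc1OCc1nnc(-c2ccc(F)cc2)o1`, share one core and differ only in that (fluoro in place of methyl on an aromatic carbon). In an ADME assay on MCF-10A cells (Homo sapiens) for cytotoxicity, read by MTT assay, with a stated time of 48 h (a lower number here means a stronger inhibitor, a higher number a weaker inhibitor), compound 1 gives no number but a limit, > 100000 nM. Compound 2 likewise reaches only a limit, > 100000 nM. The step that the two limits leave unreadable from compound 1 to compound 2 therefore cannot be read. Compound 3, `Cc1ccc(-c2nnc(COc3ccc(-c4nnco4)cc3)o2)cc1`, carries a different core; how the two cores differ is not broken down here. Compound 3 also gives only a limit, > 100000 nM. All three values sit at the limit of > 100000 nM in this assay, at which 3 of the 3 values shown sit. Compound 4, `Fc1ccc(-c2nnc(COc3ccc(-c4nnco4)cc3)o2)cc1`, repeats the same change on the core of compound 3: fluoro in place of methyl on an aromatic carbon. Resting on the unreadable step that the two limits leave unreadable from compound 1 to compound 2 and on (the limit of > 100000 nM in this assay, at which 3 of the 3 values shown sit), the step that the limit leaves unreadable from compound 3 to compound 4 is expected to be small. Compound 4 is thus estimated to land at 150000 nM in this assay.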

Compound 4, half-maximal inhibitory concentration: > 100000 nM
Compound 4 was reported as a limit (the forecaster's own chance of this, stated with the estimate: 85%); the middle value lies beyond the limit too.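

For the compounds shown here, compound 3 and compound 4 each give only a limit in this assay, so no step between them can be read: the limit of > 100000 nM in this assay, at which 4 of the 4 values shown sit.

The compounds shown leave open how far past that limit each one lies, and whether fluoro in place of methyl changes the value at all.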